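Trimming the Triazole Substituent to a Bare Hydrogen

The source may report more compounds than this note shows. Statements on the series, on what has been measured and on what is new or still open speak of the compounds shown alone.

Three compounds built on a shared core, each with a triazole ring bearing a different substituent, have been tested in a functional assay on HepG2 cells (Homo sapiens) for antiproliferative activity, read by MTT assay, with a stated time of 72 h; a lower number here means a stronger inhibitor, a higher number a weaker inhibitor. Compound 1 `C[Si](C)(C)c1cn(C[C@H](O)[C@H]2OC(=O)C(OCc3ccccc3)=C2OCc2ccccc2)nn1` gives 24100 nM. Compound 3 `O=C1O[C@H]([C@@H](O)Cn2cc(-c3cc(C(F)(F)F)cc(C(F)(F)F)c3)nn2)C(OCc2ccccc2)=C1OCc1ccccc1` gives 33800 nM, and compound 2 `O=C1O/C(=C\Cn2cc(-c3cccc(O)c3)nn2)C(OCc2ccccc2)=C1OCc1ccccc1` gives 61700 nM. Compound 1 holds the lowest of the three numbers; its gap to compound 3 lies within the scatter, so no order can be read between them, whereas its gap to compound 2 lies beyond the scatter.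

Compound 4 `O=C1O[C@H]([C@@H](O)Cn2ccnn2)C(OCc2ccccc2)=C1OCc1ccccc1` has not yet been measured in this assay. It differs from compound 1 in one place: a hydrogen atom in place of a group of 4 heavy atoms (3 carbon, 1 silicon; no ring), on an aromatic carbon. The group that leaves sits on an aromatic carbon of a five-membered aromatic ring with 3 nitrogen, next to the ring nitrogen, and a hydrogen atom takes its place.

Among the compounds with values here, no measured pair in this set shows such a step, so the expectation rests on the spread of the three numbers alone. All three substituents on the triazole give numbers of broadly the same order, and the bare ring is expected to stay in that range, with a modest step toward a higher number from compound 1 to compound 4 of about a 1.7-fold higher number from compound 1 to compound 4 (0.22 log units; within the scatter). Compound 4 is therefore estimated at 40000 nM, within a range from 15000 nM to 120000 nM.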

Compound 4, half-maximal inhibitory concentration: > 100000 nM
Compound 4 ended at the assay's limit; the forecaster's own chance of this, stated with the estimate: 20%; middle value at least 2.5-fold (0.39 log units) away from the limit.
By their numbers in this assay, from the lowest: compounds 1, 3 and 2 (each within the scatter of the next, the first and the last beyond it). At a limit, above all of these: compound 4.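

In this assay compound 4 gives > 100000 nM, which is a limit of the assay and not a number. Within the data shown here, replacing the group of 4 heavy atoms (3 carbon, 1 silicon) on the aromatic carbon with a hydrogen atom gives an at least 4.1-fold higher number from compound 1 to compound 4 (0.61 log units; beyond the scatter), the first step in this set that changes a single place, and it shows that what this carbon carries on the triazole matters in this assay, since the step lies beyond the scatter. The size of this step is only a lower bound and not a measured distance: the limit of > 100000 nM in this assay, at which 1 of the 4 values shown sits.

The compounds shown leave open whether a single methyl group or a chlorine atom on this same carbon would keep the number close to that of compound 1 or would go the way of compound 4. They also leave open whether the silicon atom itself plays any part, which a tert-butyl group, with carbon in place of the silicon, could test directly against compound 1.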